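From an unsubstituted amide to a methyl on nitrogen

The compounds below may be only part of what the source reports. "The series", "measured", "known", "first", "only" and "open" are said of these compounds alone.

In an assay on isolated protein with Bile acid receptor (Homo sapiens) as the target (on this read-out higher numbers stand for an effect only at larger amounts of compound and lower numbers for an effect already at smaller amounts), compound 1 `COC(=O)/C=C/c1cccc(N(Cc2ccc(/C=C/c3ccccc3F)cc2)C(=O)C2CCCCC2)c1` gives 64 nM, and compound 2 `COC(=O)/C=C/c1cccc(N(Cc2ccc(/C=C/c3scnc3C)cc2)C(=O)C(C)C)c1` gives 228 nM. Compound 3 `COC(=O)/C=C/c1cccc(NC(=O)C2CCCCC2)c1`, which carries a hydrogen on the amide-type nitrogen, reaches only the limit of this assay, > 1000 nM. This places it at the limit of > 1000 nM in this assay, at which 1 of the 3 values shown sits, so no number is known for it.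

Compound 4 `COC(=O)/C=C/c1cccc(N(C)C(=O)C2CCCCC2)c1` differs from compound 3 in one place: methyl in place of hydrogen on an amide-type nitrogen. Nothing measured here shows what a methyl at this position does on its own, since compound 1 and compound 2 both carry a much larger group on the same nitrogen. A step in this assay from compound 3 to compound 4 is expected to be small and, if any, toward lower numbers, a step that the limit leaves unreadable from compound 3 to compound 4. Compound 4 is therefore expected to give about 1500 nM, between 400 nM and 6000 nM, with a fair chance that only a limit is reported again.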

Compound 4, half-maximal effective concentration: > 1000 nM
Compound 4: no number, only a limit; the forecaster's own chance of this, stated with the estimate: 55%; the middle value is on the limit's open side.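

Going by these compounds alone, compound 3 and compound 4 both end at a limit, so no step between them can be read: the limit of > 1000 nM in this assay, at which 2 of the 4 values shown sit. In this assay, the compounds shown leave open what methyl in place of hydrogen on this amide-type nitrogen does on its own.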